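The source may report more compounds than this note shows. Statements on the series, on what has been measured and on what is new or still open speak of the compounds shown alone.

Three carbamate variants of one shared core have been measured in a functional assay on isolated protein for inhibition of Glucose-dependent insulinotropic receptor (Rattus norvegicus), read by HTRF and cAMP accumulation; a higher number here means a larger maximal response, a lower number a smaller maximal response. Compound 1, `Cc1nc(S(C)(=O)=O)ccc1Oc1ncnc(OC2CCN(C(=O)OC(C)C)CC2)c1F`, gives 77% in this assay. Compound 2, `Cc1nc(S(C)(=O)=O)ccc1Oc1ncnc(OC2CCN(C(=O)OC(C)(C)C#N)CC2)c1F`, reaches 97%, and compound 3, `Cc1nc(S(C)(=O)=O)ccc1Oc1ncnc(OC2CCN(C(=O)OC(C)F)CC2)c1F`, reaches 68%. Compound 3 thus sits at the low end of the three numbers: the step of a number 9 percentage points lower from compound 1 to compound 3 (within the scatter) lies within the scatter, whereas the step of a number 29 percentage points lower from compound 2 to compound 3 (beyond the scatter) lies beyond it.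

Compound 4, `Cc1nc(S(C)(=O)=O)ccc1Oc1ncnc(OC2CCN(C(=O)OC3COC3)CC2)c1F`, is the next variant: oxetan-3-yl in place of 1-fluoroethyl on an oxygen next to a carbonyl group. All three measured steps alter the group on the oxygen next to the carbonyl, so all bear on this change. The step of a number 20 percentage points higher from compound 1 to compound 2 (beyond the scatter) shows that a group carrying a nitrile at that position raises the maximal response, while the step of a number 9 percentage points lower from compound 1 to compound 3 (within the scatter) shows that the small 1-fluoroethyl group changes little. Within the data shown here, since oxetan-3-yl brings one hydrogen-bond acceptor, as the nitrile does, a modest rise is expected, though with wide uncertainty because only one such acceptor-bearing group, compound 2 with 97%, has been measured. For compound 4 the expected step is a number 10 percentage points higher from compound 3 to compound 4 (within the scatter), giving an estimated 78% with a range from 60% to 95%.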

Compound 4, largest response reached (reported as efficacy), in percent of the reference or control that the assay uses: 66%
Beside the measured number, compound 4's estimate is 12 percentage points above it; the range from low to high includes it.
By their numbers in this assay, from the lowest: compounds 4, 3 and 1 (each within the scatter of the next, the first and the last beyond it); then compound 2.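

At the oxygen next to a carbonyl group, oxetan-3-yl brings a four-membered ring and a hydrogen-bond acceptor, yet in this assay the step of a number 2 percentage points lower from compound 3 to compound 4 (within the scatter) does not separate it from 1-fluoroethyl. The step of a number 11 percentage points lower from compound 1 to compound 4 (beyond the scatter) sets it apart from isopropyl, and the step of a number 31 percentage points lower from compound 2 to compound 4 (beyond the scatter) shows that a hydrogen-bond acceptor on this group does not by itself bring the high response of compound 2, so this change adds a ring and an acceptor with no rise over compound 3. Nothing available explains why these groups differ.

The compounds shown leave open whether the high response of compound 2 belongs to its nitrile or to its branched carbon. As far as these compounds go, a tert-butyl group or a cyanomethyl group on this oxygen would separate the two, and an amine on the chain remains unexplored here.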